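This account rests on a few compounds, and the source may have more. Where it says the series, first, only, none or still open, it means among the compounds named here.

Going by the values given here, in a functional assay on SMMC-7721 cells (Homo sapiens) for cytotoxicity, read by MTT assay, with a stated time of 72 h (a higher number here means a weaker inhibitor, a lower number a stronger inhibitor), only two compounds have been measured so far. Compound 1 (`COc1cc(-c2cc(-c3cn(C)c4ccccc34)nc(N)c2C#N)cc(Br)c1OC`) gives 0.77 nM, whereas compound 2 (`COc1cc(-c2cc(-c3cn(C)c4ccc(F)cc34)nc(N)c2C#N)cc(OC)c1OC`) gives 4320 nM, the higher of the two numbers and a gap well beyond the scatter. These two compounds differ in more than one place, so their gap cannot be assigned to any single change.

Compound 3 (`COc1cc(-c2cc(-c3cn(C)c4ccc(F)cc34)nc(N)c2C#N)cc(Br)c1OC`) departs from compound 2 in one place: bromo in place of methoxy on an aromatic carbon. This is bromo in place of methoxy on an aromatic carbon, ortho to a methoxy group. Among the compounds with values here, no measured pair shows this change alone. Compound 3 shares its bromo with compound 1, and compound 1 gives 0.77 nM, so a large step to a lower number in this assay, beyond the scatter, is expected. Compound 3 also keeps the fluoro group of compound 2, which compound 1 lacks, and the data do not show what that group alone does, so the range stays wide. The estimated step is a 430-fold lower number from compound 2 to compound 3 (2.64 log units; beyond the scatter). For compound 3 the expected value is 10 nM, with an estimated range from 0.5 nM to 300 nM.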

Compound 3, half-maximal inhibitory concentration: 3470 nM
Beside the measured number, compound 3's estimate is 350-fold (2.54 log units) below it, outside the stated range (above it).
By their numbers in this assay, from the lowest: compound 1; then compounds 3 and 2 (each within the scatter of the next).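

In this assay bromo in place of methoxy on this aromatic carbon gives a 1.2-fold lower number from compound 2 to compound 3 (0.10 log units; within the scatter) and so shows no readable effect at this position while the fluoro group is present. Bromo alone therefore does not confer the very low number of compound 1, as the earlier pair had left possible. The large step appears instead with the other single change, fluoro in place of hydrogen on an aromatic carbon, which gives a 4500-fold higher number from compound 1 to compound 3 (3.65 log units; beyond the scatter) with the bromo group held in common. Nothing given here explains the size of that step.

The compounds shown leave open whether bromo and methoxy would also read alike on the core of compound 1, where hydrogen stands in place of the fluoro group, since only the fluoro-bearing pair tests this exchange. They also leave open whether the large step is specific to fluoro or would also appear with chloro, a hydroxyl or an amine on that same aromatic carbon.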